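The source may hold more compounds than are shown below. What is called first, only, known or untested is meant among the compounds shown, and "the series" means these compounds.

Measured compounds:
compound 1 `N#C/N=C1\N(CCCCCCOc2ccc(Cl)cc2)C(=O)C(c2ccccc2)N1c1ccncc1` with 44 nM
compound 2 `N#C/N=C1\N(CCCCCCCOc2ccc(Cl)cc2)C(=O)C(c2ccccc2)N1c1ccncc1` with 380 nM
compound 3 `N#C/N=C1\N(CCCCCCOc2ccc(Cl)cc2)C(=O)CCN1c1ccncc1` with 344 nM

All three were read in a functional assay on HepG2 cells (Homo sapiens) for cytotoxicity; on this read-out lower numbers stand for stronger inhibition and higher numbers for weaker inhibition. Compound 1 gives 44 nM in this assay, and the chain-lengthening gives an 8.6-fold higher number from compound 1 to compound 2 (0.94 log units; beyond the scatter). Compound 3 `N#C/N=C1\N(CCCCCCOc2ccc(Cl)cc2)C(=O)CCN1c1ccncc1` gives 344 nM; its core differs from that of compound 1, and the difference between the two cores is not broken down here. Compound 4 `N#C/N=C1\N(CCCCCCCOc2ccc(Cl)cc2)C(=O)CCN1c1ccncc1` is not yet measured; it carries the same kind of change as compound 2 does, ((4-chlorophenoxy)methyl in place of 4-chlorophenoxy on a saturated chain carbon, six bonds along the chain from an amide-type nitrogen in a ring), with the place described in the same words for both pairs. Because the step of an 8.6-fold higher number from compound 1 to compound 2 (0.94 log units; beyond the scatter) points to a weaker result on the core of compound 1, a step in the same direction is expected for compound 4, estimated as a 5.2-fold higher number from compound 3 to compound 4 (0.72 log units; beyond the scatter), though smaller, since the second core may not carry the change the same way. Compound 4 is estimated at 1800 nM, between 500 nM and 6000 nM.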

Compound 4, half-maximal inhibitory concentration: 4000 nM
Estimate against measurement, compound 4: 2.2-fold (0.35 log units) below; the measured number falls inside the stated range.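

In this assay, (4-chlorophenoxy)methyl in place of 4-chlorophenoxy gives a 12-fold higher number from compound 3 to compound 4 (1.07 log units; beyond the scatter). On these two cores the change carries over in both direction and size: the same change on two cores in this assay, an 8.6-fold higher number (0.94 log units; beyond the scatter) from compound 1 to compound 2 and a 12-fold higher number (1.07 log units; beyond the scatter) from compound 3 to compound 4, 1.3-fold (0.13 log units) apart, within the scatter of two such steps. Within the data shown here, this rests on only two matched pairs in a single assay, so it sets no rule for other cores and gives no reason for the weaker result.

From the compounds shown here alone, how a shorter chain, or an amine or a carboxylic acid in place of 4-chlorophenoxy, would read on either core remains open. Going by these compounds, whether the step would hold on a third core also remains open.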